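The compounds below may be only part of what the source reports. "The series", "measured", "known", "first", "only" and "open" are said of these compounds alone.

Compound 1 `CCOc1cc(NC(=O)NCc2cc(C)c(N3CC(C)OC(C)C3)cn2)cc(Cl)n1` gives 4200 nM in a functional assay on CHO cells for agonist activity at sphingosine 1-phosphate receptor 2 (Homo sapiens), read by fluorescence and calcium flux, with a stated time of 3 min; on this read-out higher numbers stand for weaker inhibition and lower numbers for stronger inhibition. Compound 2 `CCOc1cc(NC(=O)NCc2cc(C)c(-c3cn(C)nc3C(F)(F)F)nn2)cc(C#N)n1` gives 5500 nM in this assay. Compound 3 `CCOc1cc(NC(=O)NCc2cc(C)c(-c3cn(C)nc3C(F)(F)F)nn2)cc(C)n1` gives 4400 nM in this assay.

Compound 2 has the highest of the three numbers, but its nearest neighbour is compound 3, reached by a 1.3-fold lower number from compound 2 to compound 3 (0.10 log units; within the scatter), and the values of compound 2 and compound 1 likewise lie within the scatter of each other, so the three compounds cannot be told apart on these data.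

Compound 4 `CCOc1nc(C#N)cc(NC(=O)NCc2cc(C)c(-c3cn(C)nc3C(F)(F)F)nn2)c1C` differs from compound 2 by methyl in place of hydrogen on an aromatic carbon. For the measured compounds named here, no measured pair shows a hydrogen exchanged for a methyl on this ring. Going by the values given here, the one step available, a 1.3-fold lower number from compound 2 to compound 3 (0.10 log units; within the scatter), concerns a different exchange on the same ring and stayed within the scatter, which gives no sign that a small change here moves this assay. The expectation for compound 4 is therefore a number close to that of compound 2, the expected step being a 1.1-fold lower number from compound 2 to compound 4 (0.04 log units; within the scatter). Compound 4 is estimated at 5000 nM, with a range from 2000 nM to 13000 nM.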

Compound 4, half-maximal inhibitory concentration: 5500 nM
The estimate for compound 4 lay 1.1-fold (0.04 log units) below the measured number, and the stated range covers the measured number.
By their numbers in this assay, from the lowest: compounds 1, 3, 2 and 4 (each within the scatter of the next).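

Adding a methyl on the aromatic carbon ortho to an ethoxy group and para to a cyano group gives no change at the digits printed from compound 2 to compound 4 (within the scatter) in this assay, the first look at this position, and the read-out does not separate the two compounds. With a 1.3-fold lower number from compound 2 to compound 3 (0.10 log units; within the scatter) at the cyano-bearing carbon, two single exchanges on this ring now lie within the scatter, so neither position has yet shown an effect in this assay. Nothing available bears on why the added methyl leaves the number where it is.

As far as these compounds go, whether a longer chain such as propyl, an amine or a carboxylic acid at this position would move the number remains open. So does whether the methyl would behave the same way on the core of compound 1.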